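The source may hold more compounds than are shown below. What is called first, only, known or untested is meant among the compounds shown, and "the series" means these compounds.

Compound 3 `Cc1cccc(-n2nncc2CN2C(=O)C3(C(C#N)=C(N)Oc4c(N)cc5nc6ccccc6nc5c43)c3ccccc32)c1` was examined in a functional assay on HCT-116 cells (Homo sapiens) for antiproliferative activity, read by MTT assay, with a stated time of 48 h; a higher number here means a weaker inhibitor, a lower number a stronger inhibitor. In this assay compound 3 gives only a limit, > 50000 nM. Two related compounds were measured alongside it. Compound 1 `N#CC1=C(N)Oc2c(c3nc4ccccc4nc3c3ccccc23)C12C(=O)N(Cc1cnnn1-c1ccccc1Cl)c1ccccc12` also gives only a limit in this assay, > 50000 nM. Compound 2 `Cc1ccc(-n2nncc2CN2C(=O)C3(C(C#N)=C(N)Oc4c3c3nc5ccccc5nc3c3ccccc43)c3ccccc32)cc1C` likewise gives only a limit in this assay, > 50000 nM. Within the data shown here, the one step that can be drawn between measured compounds is a step that the two limits leave unreadable from compound 1 to compound 2, so it carries no readable size or direction. All that the numbers show is the limit of > 50000 nM in this assay, at which 3 of the 3 values shown sit, and compound 3 stands at that limit together with the other two.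

Compound 4 `N#CC1=C(N)Oc2c(N)cc3nc4ccccc4nc3c2C12C(=O)N(Cc1cnnn1-c1ccc(F)cc1)c1ccccc12` has not been measured in this assay. It differs from compound 3 in one place: 4-fluorophenyl in place of 3-methylphenyl on an aromatic nitrogen. Among the measured compounds shown here, the only measured step that touches an aryl group on an aromatic nitrogen is the unreadable one, so no measured step supplies a size or a direction for the change in hand. The expectation therefore rests on where compound 3 stands, and the expected step from compound 3 to compound 4 is a number no higher from compound 3 to compound 4 (the limit leaves the size open). Compound 4 is accordingly expected to sit at 50000 nM, within a range of 20000 nM to 100000 nM, most probably reported again as a limit rather than as a number.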

Compound 4, half-maximal inhibitory concentration: > 50000 nM
Compound 4 gave a limit, no number; the forecaster's own chance of this, stated with the estimate: 85%; the middle value sits exactly at the limit.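

Compound 3 and compound 4 both give only a limit in this assay, so the step between them cannot be read in size or direction. All the compounds shown stand at the same point: the limit of > 50000 nM in this assay, at which 4 of the 4 values shown sit. The compounds shown leave open whether any aryl group on the aromatic nitrogen changes antiproliferative activity in these cells.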